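Halogenated aryl in place of cyanophenyl: stability outlook

A few compounds are considered here, and "the series" means these few. Any claim that something is new, unique, unknown or untested is made for them only; others in the source may bear on it.

Compound 1 `N#Cc1ccc(-c2nc(NCCNc3ccc([N+](=O)[O-])c(N)n3)ncc2-c2ncc[nH]2)cc1` carries a 4-cyanophenyl on the shared core. In an ADME assay on microsomes from liver (Rattus norvegicus) for metabolic stability (a higher number here means that the compound lasts longer, a lower number that the compound disappears faster), compound 1 gives > 0.5 h, which is a limit of the assay and not a number. Compound 2 `Nc1nc(NCCNc2ncc(-c3ncc[nH]3)c(-c3ccc(F)cc3Cl)n2)ccc1[N+](=O)[O-]` gives > 0.5 h in this assay, again a limit. Compound 3 `Nc1nc(NCCNc2ncc(-c3ncc[nH]3)c(-c3ccc(Br)cc3F)n2)ccc1[N+](=O)[O-]` gives > 0.5 h in this assay, also a limit. Compound 1 therefore stands where the other two stand: the limit of > 0.5 h in this assay, at which 3 of the 3 values shown sit. The three aryl swaps among these compounds, a step that the two limits leave unreadable from compound 1 to compound 2, a step that the two limits leave unreadable from compound 1 to compound 3 and a step that the two limits leave unreadable from compound 2 to compound 3, cannot be sized, since every value involved is a limit.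

Compound 4 `Nc1nc(NCCNc2ncc(-c3ncc[nH]3)c(-c3cc(F)c(Cl)cc3Cl)n2)ccc1[N+](=O)[O-]` differs from compound 1 in one place: 2,4-dichloro-5-fluorophenyl in place of 4-cyanophenyl on an aromatic carbon. The two steps that bear on it, from compound 1 to compound 2 and from compound 1 to compound 3, both exchange the aryl group on the same carbon and both leave the value at the limit, so no step beyond the scatter is expected here. Compound 4 is accordingly expected to sit at 1 h, within 0.5 h to 3 h. The expected step that the limit leaves unreadable from compound 1 to compound 4 is thus estimated as none beyond the scatter, with a fair chance that only a limit is again reported.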

Compound 4, half-life: > 0.5 h
Compound 4: no number, only a limit; the forecaster's own chance of this, stated with the estimate: 75%; the middle value lies beyond the limit too.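

In this assay compound 4 gives > 0.5 h, again a limit and not a number. For the compounds shown here, no step between compound 4 and compound 1, compound 2 or compound 3 can be read: the limit of > 0.5 h in this assay, at which 4 of the 4 values shown sit. The compounds shown leave open how the half-lives of these four compounds compare, and whether the aryl group on the shared core changes them at all.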